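The compounds below may be only part of what the source reports. "The series", "measured", "known", "first", "only" and "open" are said of these compounds alone.

Compound 2 `CC(C)c1ccc(NCN2C(=O)c3ccccc3C2=O)cc1` stands lowest of the two compounds measured in an assay on isolated protein for inhibition of ribosomal protein S6 kinase alpha-2 (Homo sapiens), read by fluorescence, with a stated time of 20 min, tested at 10 uM (on this read-out higher numbers stand for more inhibition at the one concentration tested (going by the name of the read-out) and lower numbers for less inhibition), where compound 2 gives 46.5%. Its nearest neighbour is compound 1 `CCc1ccc(NCN2C(=O)c3ccccc3C2=O)cc1`, which in this assay gives 63%. Compound 3 `O=C1c2ccccc2C(=O)N1CNc1ccc(O)cc1` differs from compound 2 by hydroxy in place of isopropyl on an aromatic carbon. For the measured compounds named here, the one measured step, a number 16.5 percentage points lower from compound 1 to compound 2 (beyond the scatter), concerns a change at the same part of the molecule, and it ran toward weaker inhibition as the group grew. Since the change to compound 3 removes that group altogether, a return toward the level of compound 1 is expected, so that a number 8.5 percentage points higher from compound 2 to compound 3 (within the scatter) is the anticipated step. Compound 3 is therefore estimated at 55%, within 35% to 75%.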

Compound 3, a percentage reported as inhibition, at one concentration (the size of the read-out at that concentration, not a potency): 101%
Compound 3: middle estimate off by 46 percentage points, on the low side; the whole stated range lies below it.
By their numbers in this assay, from the lowest: compound 2; then compound 1; then compound 3.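

In this assay, hydroxy on the aromatic carbon para to a large group gives a number 54.5 percentage points higher from compound 2 to compound 3 (beyond the scatter) and a number 38 percentage points higher from compound 1 to compound 3 (beyond the scatter), so compound 3 stands above both alkyl compounds, beyond the scatter. Both steps exceed a number 16.5 percentage points lower from compound 1 to compound 2 (beyond the scatter), showing that exchanging the alkyl group for hydroxy at this position shifts inhibition more than going from ethyl to isopropyl. Nothing available explains this rise. Going by these compounds, whether it is particular to hydroxy, or would also appear with an amine, methoxy or plain hydrogen at this position, remains open.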